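This account rests on a few compounds, and the source may have more. Where it says the series, first, only, none or still open, it means among the compounds named here.

The compounds measured so far:

Compound 1, `CC1CCN(c2c(S(=O)(=O)c3ccccc3)cnc3ccccc23)CC1`: 89.2%
Compound 2, `CCOC(=O)C1CCN(c2c(S(=O)(=O)c3ccccc3)cnc3ccccc23)CC1`: 33%
Compound 3, `CC1CCN(c2c(S(=O)(=O)c3ccccc3)cnc3ccc(Cl)cc23)CC1`: 59%

In an assay on isolated protein for displacement of a labelled ligand from metabotropic glutamate receptor 5 (Homo sapiens), with a stated time of 60 min, tested at 1 uM (a higher number here means more inhibition at the concentration tested (going by the name of the read-out), a lower number less inhibition), compound 1 stands highest of the three numbers. Its nearest neighbour is compound 3, reached by the step of a number 30.2 percentage points lower from compound 1 to compound 3 (beyond the scatter); the furthest is compound 2, reached by the step of a number 56.2 percentage points lower from compound 1 to compound 2 (beyond the scatter). Both changes made from compound 1 therefore lowered the number by a large amount.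

Compound 4, `CCN1CCN(c2c(S(=O)(=O)c3ccccc3)cnc3ccccc23)CC1`, differs from compound 1 in one place: 4-ethylpiperazin-1-yl in place of 4-methylpiperidin-1-yl on an aromatic carbon. Neither measured step matches this change. The step from compound 1 to compound 2 alters a substituent on the same saturated ring, the step from compound 1 to compound 3 alters the aromatic part; the ring itself was never exchanged. All that the data show is that departures from compound 1 have so far cost a large part of the inhibition, so a decrease beyond the scatter is the expectation, though with wide uncertainty. Compound 4 is thus estimated at 55%, within a range from 25% to 85%. The expected step is a number 34.2 percentage points lower from compound 1 to compound 4 (beyond the scatter).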

Compound 4, a percentage reported as inhibition, at one concentration (the size of the read-out at that concentration, not a potency): 1.7%
Compound 4: middle estimate off by 53.3 percentage points, on the high side; the whole stated range lies above it.
By their numbers in this assay, from the lowest: compound 4; then compound 2; then compound 3; then compound 1.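

In this assay, replacing 4-methylpiperidin-1-yl with 4-ethylpiperazin-1-yl on the aromatic carbon opposite the ring nitrogen gives a number 87.5 percentage points lower from compound 1 to compound 4 (beyond the scatter) and leaves almost no inhibition at the concentration tested. Unlike the earlier changes, which altered a substituent on the saturated ring or on the aromatic part, this one exchanges the ring itself, and it shows that such an exchange at this position, with the rest of the core of compound 1 unchanged, can remove nearly all of the read-out. Nothing available explains this loss.

The compounds shown do not separate the second ring nitrogen from the change of methyl to ethyl, and a 4-methylpiperazin-1-yl or 4-ethylpiperidin-1-yl group would be needed to tell them apart. On these data alone, how a morpholine ring or a dimethylamino group would fare at this position also remains open.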